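Replacing an aminopyrazine with a methoxyphenyl on a shared core

The source may report more compounds than this note shows. Statements on the series, on what has been measured and on what is new or still open speak of the compounds shown alone.

Of the compounds shown here, three built on one shared core have been measured in a functional assay on HeLa cells (Homo sapiens) for cytotoxicity, read by MTT assay, with a stated time of 48 h; on this read-out lower numbers stand for stronger inhibition and higher numbers for weaker inhibition. Compound 1 `Cc1nc2c3ccccc3ccc2c2nc3c(ccc4ccccc43)c(-c3cccc([N+](=O)[O-])c3)c12` gives 50700 nM, compound 2 `Cc1nc2c3ccccc3ccc2c2nc3c(ccc4ccccc43)c(-c3cccnc3)c12` gives 3860 nM, and compound 3 `Cc1nc2c3ccccc3ccc2c2nc3c(ccc4ccccc43)c(-c3nccnc3N)c12` gives 1210 nM. Compound 3 holds the lowest number of the three: the step of a 3.2-fold lower number from compound 2 to compound 3 (0.50 log units; beyond the scatter) is modest, while the step of a 42-fold lower number from compound 1 to compound 3 (1.62 log units; beyond the scatter) is large, as is the step of a 13-fold lower number from compound 1 to compound 2 (1.12 log units; beyond the scatter).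

Compound 4 `COc1ccc(-c2c3ccc4ccccc4c3nc3c2c(C)nc2c4ccccc4ccc32)cc1` has not yet been measured. It differs from compound 3 in one place: 4-methoxyphenyl in place of 3-aminopyrazin-2-yl on an aromatic carbon. The group that leaves carries 1 hydrogen-bond donor and 3 hydrogen-bond acceptors; the group that enters is a six-membered aromatic ring of carbon only with 0 hydrogen-bond donors and 1 hydrogen-bond acceptor. The measured steps that bear on this change are a 42-fold lower number from compound 1 to compound 3 (1.62 log units; beyond the scatter) and a 3.2-fold lower number from compound 2 to compound 3 (0.50 log units; beyond the scatter), both of which moved toward the 3-aminopyrazin-2-yl group and both of which lowered the number, and the only other carbon-only ring, in compound 1, gave the highest value of all. On this basis the expected step is a 6.6-fold higher number from compound 3 to compound 4 (0.82 log units; beyond the scatter), toward a weaker result. Compound 4 is estimated at 8000 nM in this assay, within a range from 2000 nM to 40000 nM.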

Compound 4, half-maximal inhibitory concentration: 45900 nM
Compound 4: the middle estimate sits 5.7-fold (0.76 log units) below what was measured; measured number outside the range, above it.
By their numbers in this assay, from the lowest: compound 3; then compound 2; then compounds 4 and 1 (each within the scatter of the next).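

In this assay this position proves far less tolerant of a carbon-only ring than compound 1 alone could show: a 38-fold higher number from compound 3 to compound 4 (1.58 log units; beyond the scatter) and a 12-fold higher number from compound 2 to compound 4 (1.08 log units; beyond the scatter) are both large steps away from rings that contain nitrogen. Among the compounds shown here, the third comparison, a 1.1-fold lower number from compound 1 to compound 4 (0.04 log units; within the scatter), leaves the two carbon-only rings impossible to tell apart, although 3-nitrophenyl and 4-methoxyphenyl carry very different substituents, so the high number of compound 1 is not peculiar to its nitro group; across these four compounds, both nitrogen-containing rings give lower numbers than both carbon-only rings, and no compound goes against this. Nothing in the data shown explains why the type of ring matters so much at this position.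

As far as these compounds go, what remains open is whether the ring nitrogens or the amine of 3-aminopyrazin-2-yl account for the lowest number, held by compound 3. A pyrazin-2-yl ring without the amine, or a phenyl ring carrying an amine, would pull these two features apart and show whether a carbon-only ring can work here at all.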